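The source may report more compounds than this note shows. Statements on the series, on what has been measured and on what is new or still open speak of the compounds shown alone.

Three compounds have been measured in a physicochemical assay for lipophilicity, at pH 7.4; a lower number here means a more polar compound, a higher number a more lipophilic compound:

Compound 1, `CNC(=O)c1cc(C(=O)N[C@H]2[C@@H]3C[C@@H](O)C[C@@H]32)cc2c1OC[C@H]2c1ccccc1`, gives 2.9.
Compound 2, `CNC(=O)c1cc(C(=O)NC)c2c(c1)[C@H](c1ccccc1)CO2`, gives 3.2.
Compound 3, `CNC(=O)c1cc(C(=O)NC)c2c(c1)[C@](C)(c1ccccc1)CO2`, gives 3.4.

Compound 2 and compound 1 share a core and differ in one place: a group of 7 heavy atoms (6 carbon, 1 oxygen; one three-membered non-aromatic ring of carbon only, one five-membered non-aromatic ring of carbon only) in place of one carbon atom, on an amide-type nitrogen. This change gave a step of a number 0.30 log units lower from compound 2 to compound 1 (within the scatter). The numbers of compound 2 and compound 3 lie within the scatter of each other, so nothing can be said about their order; the number of compound 1 lies beyond the scatter of compound 3. The difference between the core of compound 2 and the core of compound 3 is not broken down here.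

Compound 4, `CNC(=O)c1cc(C(=O)N[C@H]2[C@@H]3C[C@@H](O)C[C@@H]32)cc2c1OC[C@@]2(C)c1ccccc1`, has not yet been measured in this assay. It is related to compound 3 by a group of 7 heavy atoms (6 carbon, 1 oxygen; one three-membered non-aromatic ring of carbon only, one five-membered non-aromatic ring of carbon only) in place of one carbon atom, on an amide-type nitrogen. The place of this change is the same word for word as in the pair of compound 2 and compound 1, so it is the same change, seen for the second time among these compounds. Because the earlier step was a number 0.30 log units lower from compound 2 to compound 1 (within the scatter), a step of about the same size is expected here. The estimated step is a number 0.30 log units lower from compound 3 to compound 4 (within the scatter). That expectation rests on a single earlier pair, so its size is uncertain. Compound 4 is expected to give about 3.1, with the number estimated to fall between 2.7 and 3.5.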

Compound 4, distribution coefficient: 3.3
The estimate for compound 4 lay 0.20 log units below the measured number, and the stated range covers the measured number.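

In this assay, the same change on the amide-type nitrogen, with methyl leaving and the group with two carbon rings entering, gave a step of a number 0.30 log units lower from compound 2 to compound 1 (within the scatter) on the core of compound 2 and a step of a number 0.10 log units lower from compound 3 to compound 4 (within the scatter) on the core of compound 3, so neither of the two pairs shows a step beyond the scatter. This does not show that the change leaves the number untouched, since a step within the scatter cannot be told apart from the ordinary spread of repeated measurements, and two pairs cannot say how the same change would behave on a third core. No measurement offered here explains these numbers.

The compounds shown leave open how this assay would respond to a group of a different kind on the amide-type nitrogen, such as an amine, a carboxylic acid or a longer chain in place of methyl. They also leave open whether the entering group would give a step beyond the scatter on any core other than the two seen here.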